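Pyridinyl for Cyclohexyl on the Ring Amine Nitrogen

The source may hold more compounds than are shown below. What is called first, only, known or untested is meant among the compounds shown, and "the series" means these compounds.

Compound 1 `O=C(CN1CCN(C2CCCCC2)CC1)Nc1nc2c(s1)CCCC2`: > 1000 nM
Compound 2 `CC1CCc2sc(NC(=O)CN3CCN(c4ccc(F)cc4)CC3)nc2C1`: 26 nM

In an assay on isolated protein for inhibition of long-chain fatty acid transport protein 1 (Homo sapiens), read by scintillation counting, with a stated time of 20 min (on this read-out lower numbers stand for stronger inhibition and higher numbers for weaker inhibition), compound 1 reaches only a limit of the assay, > 1000 nM. Compound 1 therefore stands at the limit of > 1000 nM in this assay, at which 1 of the 2 values shown sits. Compound 2, which carries an aromatic ring on the ring amine nitrogen and a methyl on its core, gives 26 nM in this assay. Compound 3 `O=C(CN1CCN(c2ccncc2)CC1)Nc1nc2c(s1)CCCC2` is not yet measured; it differs from compound 1 by pyridin-4-yl in place of cyclohexyl on an amine nitrogen in a ring. Given that compound 2 gives 26 nM with an aromatic ring at that nitrogen, compound 3 is expected to move beyond the scatter toward stronger inhibition, an estimated step of an at least 5.0-fold lower number from compound 1 to compound 3 (0.69 log units; beyond the scatter). Compound 3 is thus estimated at 200 nM, between 40 nM and 1500 nM.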

Compound 3, half-maximal inhibitory concentration: > 1000 nM
Compound 3 gave a limit, no number; the forecaster's own chance of this, stated with the estimate: 25%; middle value at least 5.0-fold (0.69 log units) from the limit.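

In this assay compound 3 gives > 1000 nM, a limit and not a number, as compound 1 also does, so no step between these two compounds can be read: the limit of > 1000 nM in this assay, at which 2 of the 3 values shown sit.

From the compounds shown here alone, whether pyridin-4-yl and cyclohexyl on that ring amine nitrogen differ at all in this assay stays open.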